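A few compounds are considered here, and "the series" means these few. Any claim that something is new, unique, unknown or untested is made for them only; others in the source may bear on it.

Compound 1 `CCCOC(=O)N1CCC(Oc2ncnc3c2CCN3c2ccc(S(C)(=O)=O)cc2F)CC1`: 111%
Compound 2 `CCS(=O)(=O)N1CCC(Oc2ncnc3c2CCN3c2ccc(S(C)(=O)=O)cc2F)CC1`: 51%

For the measured compounds named here, in a functional assay on CHO-K1 cells with Glucose-dependent insulinotropic receptor (Homo sapiens) as the target, read by a luciferase reporter, with a stated time of 5 h (on this read-out lower numbers stand for smaller maximal responses and higher numbers for larger maximal responses), compound 2 gives 51%, the lowest of the two numbers measured; its only neighbour, compound 1, gives 111%. Compound 3 `CS(=O)(=O)c1ccc(N2CCc3c(OC4CCN(C5=NCCCN5)CC4)ncnc32)c(F)c1` has not been measured yet. It differs from compound 2 in one place: a group of 6 heavy atoms (4 carbon, 2 nitrogen; one six-membered non-aromatic ring with 2 hetero atoms) in place of a group of 5 heavy atoms (2 carbon, 2 oxygen, 1 sulfur; no ring), on an amine nitrogen in a ring. Going by the values given here, the one measured step, a number 60 percentage points lower from compound 1 to compound 2 (beyond the scatter), concerns the same ring nitrogen and shows that exchanging the group at that place can shift the maximal response by a large amount. Among the compounds with values here, no measured step exchanges the ethylsulfonyl for a ring group, so the direction for compound 3 cannot be read from the data, only that a large step is possible. Compound 3 is therefore expected to give about 70%, within 30% to 120%. That estimate means a step of a number 19 percentage points higher from compound 2 to compound 3 (beyond the scatter), expected with wide uncertainty.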

Compound 3, largest response reached (reported as percent of maximum), in percent of the reference or control that the assay uses: 66%
For compound 3 the middle estimate is 4 percentage points above the measured one, within the range that was stated.
By their numbers in this assay, from the lowest: compound 2; then compound 3; then compound 1.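

In this assay, a second kind of group on this ring nitrogen gives a number 15 percentage points higher from compound 2 to compound 3 (beyond the scatter), so the ethylsulfonyl result is not the lowest response this position can be moved away from, and a ring group is tolerated there. The same ring group still gives a number 45 percentage points lower from compound 1 to compound 3 (beyond the scatter), leaving the propoxycarbonyl of compound 1 clearly ahead of both other groups. Nothing available explains these differences.

Going by these compounds, whether a shorter ethoxycarbonyl, a longer butoxycarbonyl or a plain propyl chain on this nitrogen would stay close to compound 1 remains open. Also open, on these data alone, is whether the ring itself or its hydrogen-bond donor matters in compound 3, as the two enter together in this single change.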